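A Piperidine in Place of the Benzyl Phenyl Ring

The source may hold more compounds than are shown below. What is called first, only, known or untested is meant among the compounds shown, and "the series" means these compounds.

Compound 1 `c1ccc2c(c1)CN[C@@H](CN(CCCCNCc1ccncc1)[C@H]1CCCc3cccnc31)C2` gives > 30000 nM in a functional assay on cells for agonist activity at C-X-C chemokine receptor type 4 (Homo sapiens), read by fluorescence and calcium flux, with a stated time of 90 s; a higher number here means that more compound is needed for the effect, a lower number that less compound is needed; this is a limit, not a number.
Compound 2 `c1ccc(CNCCCCN(C[C@H]2Cc3ccccc3CN2)[C@H]2CCCc3cccnc32)cc1` gives > 30000 nM in this assay; this too is a limit.

Compound 1 and compound 2 share one core and differ only in the aromatic ring attached to the saturated chain carbon bound to an amine nitrogen, phenyl in compound 2 where compound 1 carries pyridin-4-yl. The step that the two limits leave unreadable from compound 1 to compound 2 cannot be read in size or direction, because both values sit at the limit (the limit of > 30000 nM in this assay, at which 2 of the 2 values shown sit). Compound 2 therefore stands at the limit, with no number below it known, and no readable step exists in this set.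

Compound 3 `c1ccc2c(c1)CN[C@@H](CN(CCCCNCC1CCNCC1)[C@H]1CCCc3cccnc31)C2` differs from compound 2 by piperidin-4-yl in place of phenyl on a saturated chain carbon bound to an amine nitrogen. Among the measured compounds shown here, no measured step bears on this change, since the one step available is unreadable. With compound 2 at the limit, compound 3 is expected most likely to remain at the limit as well; the estimate for compound 3 is 30000 nM, with a range from 5000 nM to 100000 nM. The expected step is a number no higher from compound 2 to compound 3 (the limit leaves the size open), which amounts to no confident change beyond the scatter.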

Compound 3, half-maximal effective concentration: > 30000 nM
Compound 3: no number, only a limit; the forecaster's own chance of this, stated with the estimate: 75%; the middle value sits exactly at the limit.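

Neither the change from compound 2 to compound 3 nor that from compound 1 to compound 3 gives a readable step, because all three compounds stand at one limit: the limit of > 30000 nM in this assay, at which 3 of the 3 values shown sit.

The compounds shown leave open whether phenyl, pyridin-4-yl and piperidin-4-yl differ at all in this assay, and which change to the shared core would yield a number rather than a limit.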